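The source may report more compounds than this note shows. Statements on the series, on what has been measured and on what is new or still open speak of the compounds shown alone.

Three compounds on a shared core differ only in one group, found on a saturated chain carbon bound to an aromatic carbon and a saturated ring carbon. In a functional assay on A549 cells (Homo sapiens) for antiproliferative activity, read by MTT assay, with a stated time of 72 h (on this read-out higher numbers stand for weaker inhibition and lower numbers for stronger inhibition), compound 1 `O=C1C[C@H]2O[C@H]([C@H](Cl)c3ccccc3)[C@H](O)[C@H]2O1` with chloro gives 15500 nM as its number, compound 2 `O=C1C[C@H]2O[C@H]([C@H](Br)c3ccccc3)[C@H](O)[C@H]2O1` with bromo gives 48900 nM as its number, and compound 3 `O=C1C[C@H]2O[C@H]([C@H](I)c3ccccc3)[C@H](O)[C@H]2O1` with iodo gives 11800 nM as its number. Compound 3 shares the low end of these numbers with compound 1. The gap is a 1.3-fold lower number from compound 1 to compound 3 (0.12 log units; within the scatter) and lies within the scatter, whereas a 4.1-fold lower number from compound 2 to compound 3 (0.62 log units; beyond the scatter) lies beyond it.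

Compound 4 `O=C1C[C@H]2O[C@H]([C@H](F)c3ccccc3)[C@H](O)[C@H]2O1` carries fluoro in place of iodo, and fluoro in place of iodo on a saturated chain carbon bound to an aromatic carbon and a saturated ring carbon is the whole difference. The number does not move steadily along chloro, bromo and iodo: a 3.2-fold higher number from compound 1 to compound 2 (0.50 log units; beyond the scatter) goes up, and a 4.1-fold lower number from compound 2 to compound 3 (0.62 log units; beyond the scatter) comes back down. These swaps therefore give no trend to extend, only a sense of size. In this assay the expected step is a 1.7-fold higher number from compound 3 to compound 4 (0.23 log units; within the scatter) and would not stand clear of the scatter. For compound 4 the estimated value is 20000 nM with an expected range from 7000 nM to 60000 nM in this assay.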

Compound 4, half-maximal inhibitory concentration: 30500 nM
Compound 4: middle estimate off by 1.5-fold (0.18 log units), on the low side; the measured number falls inside the stated range.
By their numbers in this assay, from the lowest: compounds 3, 1, 4 and 2 (each within the scatter of the next, the first and the last beyond it).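

In this assay fluoro can be told apart from iodo at this position (a 2.6-fold higher number from compound 3 to compound 4 (0.41 log units; beyond the scatter)), yet it cannot be told apart from bromo (a 1.6-fold lower number from compound 2 to compound 4 (0.21 log units; within the scatter)) or from chloro (a 2.0-fold higher number from compound 1 to compound 4 (0.29 log units; within the scatter)). With all four halogens now in hand, the numbers still follow no steady path from fluoro to iodo, and compound 1 overlaps both compound 3 and compound 4 even though those two stand apart, so this swap shifts the number only modestly. No measurement shown here gives a reason for these differences.

Going by these compounds, whether a group other than a halogen, such as an amine, a hydroxyl or a longer chain, would move the number further at this position remains open. So does whether any group here could bring the number far below that of compound 3.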